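A few compounds are considered here, and "the series" means these few. Any claim that something is new, unique, unknown or untested is made for them only; others in the source may bear on it.

Working notes on the series. The shared core of compound 1 `Nc1nccc2cc(CNCCNc3ccccc3)ccc12` carries a chain ending in an anilino group; in an assay on isolated protein for inhibition of Rho-associated protein kinase 1 (Homo sapiens), read by fluorescence polarization (on this read-out lower numbers stand for stronger inhibition and higher numbers for weaker inhibition), compound 1 gives 1480 nM. Among the compounds with values here, the only other measured member is compound 2 `Nc1nccc2cc(OC3CCNCC3)ccc12`, which in this assay gives 3630 nM. Of these two numbers compound 1 holds the lower one, and the gap to compound 2 is beyond the scatter, so compound 1 stands as the stronger inhibitor of the measured pair.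

Compound 3 `Nc1nccc2cc(CNCCOc3ccccc3)ccc12` has not yet been measured in this assay. Relative to compound 1 the change is phenoxy in place of anilino on a saturated chain carbon, two bonds along the chain from an amine nitrogen. Within the data shown here, no measured pair shows this change, so there is no directly comparable step on record; the expectation rests on the size of the group being kept and a donor being given up. For compound 3 the step is estimated as a 1.4-fold higher number from compound 1 to compound 3 (0.13 log units; within the scatter), a small move toward a higher number that may not exceed the scatter. In this assay compound 3 is expected to give 2000 nM, with a range from 700 nM to 6000 nM.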

Compound 3, half-maximal inhibitory concentration: 589 nM
Compound 3: the middle estimate sits 3.4-fold (0.53 log units) above what was measured; measured number below the stated range.
By their numbers in this assay, from the lowest: compound 3; then compound 1; then compound 2.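

In this assay, phenoxy in place of anilino on a saturated chain carbon, two bonds along the chain from an amine nitrogen, gives a 2.5-fold lower number from compound 1 to compound 3 (0.40 log units; beyond the scatter), the first step read at this position in the series. The two groups match in heavy atoms and hydrogen-bond acceptors and differ in that anilino carries a hydrogen-bond donor and phenoxy carries none, so on this pair the donor is not needed to reach the inhibition seen with compound 1. Nothing on hand explains why the swap lowers the number, and this single pair cannot separate the loss of the donor from the change of nitrogen to oxygen as such.

Open, on these data alone, is whether a benzyl group or a phenylthio group at the same place would follow phenoxy or anilino, which would show if the step is tied to the linking atom at all. Also open, as far as these compounds go, is whether a longer chain, or a fluorine or methoxy group on the phenyl ring of phenoxy, would move the number further from that of compound 3.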